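Enantiomeric cyclopropyl amide on the diazabicyclic core

The source may hold more compounds than are shown below. What is called first, only, known or untested is meant among the compounds shown, and "the series" means these compounds.

In an assay on SH-EP1 cells for agonist activity at Neuronal acetylcholine receptor; alpha4/beta2 (Homo sapiens), read by FLIPR and calcium flux (on this read-out higher numbers stand for an effect only at larger amounts of compound and lower numbers for an effect already at smaller amounts), compound 1 `CC(C)C(=O)N1CC2CC(C1)N2` gives 19000 nM. Compound 2 `C[C@@H]1C[C@@H]1C(=O)N1CC2CC(C1)N2` carries a cyclopropyl group on the carbonyl carbon where compound 1 carries an isopropyl group, and in this assay compound 2 gives 2100 nM; the step of a 9.0-fold lower number from compound 1 to compound 2 (0.96 log units; beyond the scatter). Compound 2 thus stands at the lowest of the two numbers shown, with compound 1 as its only neighbour.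

Compound 3 `C[C@H]1C[C@H]1C(=O)N1CC2CC(C1)N2` differs from compound 2 only in configuration: the two compounds have the same atoms and bonds; at least one stereo element is drawn with a configuration in one of them and without one in the other: 2 of 4 stereo elements differ; a stereocentre at a saturated ring carbon is drawn R in compound 2 and S in compound 3; a stereocentre at a saturated ring carbon is drawn S in compound 2 and R in compound 3. Among the measured compounds shown here, no measured step inverts a stereocentre, so the step from compound 1 to compound 2, a change of group rather than of configuration, does not bear directly on it. Enantiomers of the same amide may give equal or widely differing numbers; with no guide in the data, the number for compound 3 in this assay is expected near that of compound 2, with a broad range, as a 2.1-fold higher number from compound 2 to compound 3 (0.33 log units; beyond the scatter). The estimate for compound 3 is 4500 nM, between 800 nM and 30000 nM.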

Compound 3, half-maximal effective concentration: 2200 nM
Compound 3: the middle estimate sits 2.0-fold (0.31 log units) above what was measured; the range from low to high includes it.
By their numbers in this assay, from the lowest: compounds 2 and 3 (each within the scatter of the next); then compound 1.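

Among the compounds shown here, the configuration of the 2-methylcyclopropyl group on the carbonyl carbon can now be read for the first time: the swap of both drawn ring stereocentres gives a 1.0-fold higher number from compound 2 to compound 3 (0.02 log units; within the scatter) and so separates the two forms by no more than the usual scatter. The lower number relative to isopropyl is thus not tied to one drawn form, since an 8.6-fold lower number from compound 1 to compound 3 (0.94 log units; beyond the scatter) stands alongside a 9.0-fold lower number from compound 1 to compound 2 (0.96 log units; beyond the scatter) as a step of much the same size. This reading of the pair carries one caveat about what is drawn: the fact that one of compounds 2 and 3 is drawn with a defined configuration and the other without, at the place where they differ.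

Whether the methyl group on the cyclopropyl ring contributes to these numbers stays open, as a plain cyclopropyl group on the carbonyl carbon is not among the compounds shown. Also open, as far as these compounds go, is how a phenyl ring or a longer chain at this place would compare.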